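This account rests on a few compounds, and the source may have more. Where it says the series, first, only, none or still open, it means among the compounds named here.

In a functional assay on MDA-MB-231 cells (Homo sapiens) for antiproliferative activity, with a stated time of 72 h (a lower number here means that less compound is needed, a higher number that more compound is needed for the effect), compound 1 `O=C(O)c1ccc(N(Cc2ccc(C3CCCCC3)cc2)C(=O)[C@H]2CCN2S(=O)(=O)c2c(F)c(F)c(F)c(F)c2F)c(F)c1` reads > 10000 nM, which is a limit of the assay and not a number. Compound 2 `O=C(NO)c1ccc(N(Cc2ccc(C3CCCCC3)cc2)C(=O)[C@H]2CCN2S(=O)(=O)c2c(F)c(F)c(F)c(F)c2F)cc1` gives 5000 nM and compound 3 `O=C(NO)c1ccc(N(Cc2ccc(C3CCCCC3)cc2)C(=O)[C@H]2CCN2S(=O)(=O)c2c(F)c(F)c(F)c(F)c2F)cc1O` gives 5100 nM, so these two stand level, with a 1.0-fold higher number from compound 2 to compound 3 (0.01 log units; within the scatter). Compound 4 `O=C([C@H]1CCN1S(=O)(=O)c1c(F)c(F)c(F)c(F)c1F)N(Cc1ccc(C2CCCCC2)cc1)c1ccc2c(=O)[nH]ccc2c1` differs from compound 3 on the amide-type nitrogen: a group of 11 heavy atoms (9 carbon, 1 nitrogen, 1 oxygen; one six-membered aromatic ring of carbon only, one six-membered aromatic ring with 1 hetero atom) in place of a group of 11 heavy atoms (7 carbon, 1 nitrogen, 3 oxygen; one six-membered aromatic ring of carbon only), on an amide-type nitrogen. The closest evidence comes from changes at that same place, an at least 2.0-fold lower number from compound 1 to compound 2 (0.30 log units; that floor lies within the scatter) and an at least 1.9-fold lower number from compound 1 to compound 3 (0.29 log units; that floor lies within the scatter), and both floors lie within the scatter. Compound 4, like compound 1, lacks the hydroxycarbamoyl group, so a small move towards a higher number is expected, near the scatter. The expected step is a 1.6-fold higher number from compound 3 to compound 4 (0.20 log units; within the scatter). For compound 4 the estimated value is 8000 nM, within an expected range of 3000 nM to 20000 nM.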

Compound 4, half-maximal effective concentration: 1400 nM
Compound 4: middle estimate off by 5.7-fold (0.76 log units), on the high side, and the stated range ends above it.
By their numbers in this assay, from the lowest: compound 4; then compounds 2 and 3 (each within the scatter of the next). At a limit, above all of these: compound 1.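

In this assay, the earlier changes on the amide-type nitrogen could not be told from the scatter, but this group, which has no hydroxycarbamoyl, gives steps beyond it: a 3.6-fold lower number from compound 3 to compound 4 (0.56 log units; beyond the scatter) and a 3.6-fold lower number from compound 2 to compound 4 (0.55 log units; beyond the scatter). Among the compounds shown, a hydroxycarbamoyl group is therefore not required for the lowest number at this place. The step of an at least 7.1-fold lower number from compound 1 to compound 4 (0.85 log units; beyond the scatter) is only a floor, because compound 1 stands at a limit of the assay: the limit of > 10000 nM in this assay, at which 1 of the 4 values shown sits.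

The compounds shown leave open which part of the entering group goes with the lower number. They also leave open whether an amine or a nitrile on the phenyl ring at this nitrogen would read like compound 4.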